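This account rests on a few compounds, and the source may have more. Where it says the series, first, only, none or still open, it means among the compounds named here.

In a functional assay on MOLT-4 cells (Homo sapiens) for antiproliferative activity (on this read-out lower numbers stand for stronger inhibition and higher numbers for weaker inhibition), compound 1 `COc1cc(C(=O)c2sc(-c3ccc(Br)cc3)cc2N)cc(OC)c1OC` gives 92 nM, compound 2 `COc1cc(C(=O)c2sc(-c3cccc([N+](=O)[O-])c3)cc2N)cc(OC)c1OC` gives 7.5 nM and compound 3 `COc1cc(C(=O)c2sc(-c3ccsc3)cc2N)cc(OC)c1OC` gives 8.8 nM. Compound 3 therefore stands level with compound 2, as a 1.2-fold higher number from compound 2 to compound 3 (0.07 log units; within the scatter) shows, and far from compound 1. Compound 4 `COc1cc(C(=O)c2sc(-c3ccc(C)cc3)cc2N)cc(OC)c1OC` differs from compound 3 as follows: 4-methylphenyl in place of thiophen-3-yl on an aromatic carbon. In short, 4-methylphenyl replaces thiophen-3-yl on an aromatic carbon next to the ring sulfur. The closest guide is compound 1, whose 4-bromophenyl resembles the entering group, and the large 10-fold lower number from compound 1 to compound 3 (1.02 log units; beyond the scatter) runs opposite to this change. A similar large size appears in a 12-fold lower number from compound 1 to compound 2 (1.09 log units; beyond the scatter). No measurement shows how closely 4-methylphenyl follows 4-bromophenyl, so a moderate rise is expected in this assay, namely a 4.0-fold higher number from compound 3 to compound 4 (0.60 log units; beyond the scatter). For compound 4 the estimated value is 35 nM, with an expected range of 9 nM to 140 nM.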

Compound 4, half-maximal inhibitory concentration: 16 nM
Compound 4: middle estimate off by 2.2-fold (0.34 log units), on the high side, and the stated range covers the measured number.
By their numbers in this assay, from the lowest: compounds 2, 3 and 4 (each within the scatter of the next, the first and the last beyond it); then compound 1.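

In this assay, 4-methylphenyl on this aromatic carbon sits level with thiophen-3-yl (a 1.8-fold higher number from compound 3 to compound 4 (0.26 log units; within the scatter)), while the step against 3-nitrophenyl is modest but beyond the scatter (a 2.1-fold higher number from compound 2 to compound 4 (0.33 log units; beyond the scatter)). The clearest new finding comes from keeping the phenyl ring and changing only its substituent, since methyl in place of bromo already shifts the number (a 5.8-fold lower number from compound 1 to compound 4 (0.76 log units; beyond the scatter)). A phenyl ring here is therefore not tied to the weaker result of compound 1.

No measured evidence explains these differences. On these data alone, whether an amine or a carboxylic acid in place of the methyl of compound 4 would hold this activity stays open.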